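Hydrazone Variation on a Shared Core Against Monoamine Oxidase B

The source may report more compounds than this note shows. Statements on the series, on what has been measured and on what is new or still open speak of the compounds shown alone.

Measured compounds:
Compound 1, `C/C(=N\Nc1nc2ccccc2nc1Cc1ccccc1)c1ccccc1`, 980000 nM
Compound 2, `C/C(=N\Nc1nc2ccccc2nc1Cc1ccccc1)c1ccc(O)cc1`, 8400000 nM
Compound 3, `C/C(=N\Nc1nc2ccccc2nc1Cc1ccccc1)c1ccc(N)cc1`, 860000 nM

Three compounds sharing one core were tested in an assay on isolated protein for inhibition of Amine oxidase [flavin-containing] B (Homo sapiens), read by spectrophotometry; on this read-out higher numbers stand for weaker inhibition and lower numbers for stronger inhibition. Compound 1 gives 980000 nM, which is the second highest of the three numbers; compound 3 is nearest with a 1.1-fold lower number from compound 1 to compound 3 (0.06 log units; within the scatter), and compound 2 is furthest with an 8.6-fold higher number from compound 1 to compound 2 (0.93 log units; beyond the scatter). The step from compound 2 to compound 3 is a 9.8-fold lower number from compound 2 to compound 3 (0.99 log units; beyond the scatter).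

The unmeasured compound 4, `Cc1ccsc1/C=N/Nc1nc2ccccc2nc1Cc1ccccc1`, differs from compound 1 by a group of 8 heavy atoms (6 carbon, 1 nitrogen, 1 sulfur; one five-membered aromatic ring with 1 hetero atom) in place of a group of 9 heavy atoms (8 carbon, 1 nitrogen; one six-membered aromatic ring of carbon only), on a nitrogen on an aromatic ring. Within the data shown here, none of the measured steps alters this part of the molecule: all three concern a single group on the six-membered aromatic ring that now leaves, and the only large movements among them, an 8.6-fold higher number from compound 1 to compound 2 (0.93 log units; beyond the scatter) and a 9.8-fold lower number from compound 2 to compound 3 (0.99 log units; beyond the scatter), involve the hydroxy group, which compound 4 does not carry. The data therefore offer no direct guide, and the expectation rests on compound 1 alone. Compound 4 is estimated to stay close to compound 1, with an expected step of a 1.0-fold higher number from compound 1 to compound 4 (0.01 log units; within the scatter), not clearly beyond the scatter in either direction. The estimate for compound 4 in this assay is 1000000 nM, with a range from 300000 nM to 3500000 nM.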

Compound 4, half-maximal inhibitory concentration: 860000 nM
Compound 4: middle estimate off by 1.2-fold (0.07 log units), on the high side, and the stated range covers the measured number.
By their numbers in this assay, from the lowest: compounds 3, 4 and 1 (each within the scatter of the next); then compound 2.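

In this assay, among these compounds, the earlier compounds changed only a single group on the six-membered aromatic ring, whereas compound 4 replaces the whole group of 9 heavy atoms, ring included, with a group of 8 heavy atoms built on a five-membered aromatic ring with 1 hetero atom, and the outcome is a 1.1-fold lower number from compound 1 to compound 4 (0.06 log units; within the scatter). Among the compounds shown here, this place, on a nitrogen on an aromatic ring, therefore accepts an exchange of the entire ring group with no shift beyond the scatter, and compound 2, with its hydroxy group, remains the only compound whose steps go beyond it. Nothing in the available data gives a reason why the two groups read alike.

The compounds shown leave open whether a hydroxy group on the five-membered aromatic ring would move the number as it does in an 8.6-fold higher number from compound 1 to compound 2 (0.93 log units; beyond the scatter). They also leave open whether the same holds for other groups at this place, such as a cyclohexyl ring or a ring carrying a carboxylic acid.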